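Amide-nitrogen substituent variation on the shared core

This account rests on a few compounds, and the source may have more. Where it says the series, first, only, none or still open, it means among the compounds named here.

Compound 2 `C#CCn1cc(C(=O)NC(CC(=O)Nc2ccccn2)c2ccccc2)c(=O)c2cc(F)c(Cl)nc21` in a functional assay on HBL-100 cells (Homo sapiens) for cytotoxicity, read by MTT assay, with a stated time of 72 h (on this read-out lower numbers stand for stronger inhibition and higher numbers for weaker inhibition), gives > 10000 nM, which is a limit of the assay and not a number (the limit of > 10000 nM in this assay, at which 1 of the 2 values shown sits). Compound 1 `C#CCn1cc(C(=O)NC(CC(=O)Nc2ccccc2)c2ccccc2)c(=O)c2cc(F)c(Cl)nc21` in this assay gives 9300 nM. The step of an at least 1.0-fold higher number from compound 1 to compound 2 (0.03 log units; that floor lies within the scatter) lies within the scatter. Compound 3 `C#CCn1cc(C(=O)NC(CC(=O)NC2CCCC2)c2ccccc2)c(=O)c2cc(F)c(Cl)nc21` differs from compound 2 by cyclopentyl in place of pyridin-2-yl on an amide-type nitrogen. Going by the values given here, no measured step covers this change, and the single measured step, an at least 1.0-fold higher number from compound 1 to compound 2 (0.03 log units; that floor lies within the scatter), ends at a limit, so no change beyond the scatter is expected in this assay. Compound 3 is expected at 10000 nM, between 4000 nM and 30000 nM. The estimated step is a number no higher from compound 2 to compound 3 (the limit leaves the size open).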

Compound 3, half-maximal inhibitory concentration: 2000 nM
The estimate for compound 3 lay 5.0-fold (0.70 log units) above the measured number, and the stated range ends above it.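

Going by these compounds alone, on the amide-type nitrogen, cyclopentyl gives the first change beyond the scatter in this assay: a 4.7-fold lower number from compound 1 to compound 3 (0.67 log units; beyond the scatter), and an at least 5.0-fold lower number from compound 2 to compound 3 (0.69 log units; beyond the scatter). The second step is only a floor, since compound 2 stands at a limit of the assay: the limit of > 10000 nM in this assay, at which 1 of the 3 values shown sits.

Here, a non-aromatic ring of carbon only goes with a lower number than phenyl or pyridin-2-yl. The compounds shown leave open how cyclopropyl, cyclohexyl or an open-chain tert-butyl would read on this nitrogen, and so whether the lower number belongs to cyclopentyl alone or to non-aromatic groups more widely.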